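A few compounds are considered here, and "the series" means these few. Any claim that something is new, unique, unknown or untested is made for them only; others in the source may bear on it.

For the measured compounds named here, compound 2 `O=C(CSc1nnc(-c2ccncc2)n1-c1ccccc1)N/N=C/c1ccccc1F` is one of two compounds measured in a functional assay on MCF7 cells (Homo sapiens) for inhibition, read by MTT assay, with a stated time of 48 h (on this read-out lower numbers stand for stronger inhibition and higher numbers for weaker inhibition), and in it compound 2 gives 22400 nM. Going by the values given here, the only other measured compound, compound 1 `O=C(CSc1nnc(-c2ccncc2)n1-c1ccccc1)N/N=C/c1ccc([N+](=O)[O-])cc1`, gives 15300 nM in the same test, and the step of a 1.5-fold higher number from compound 1 to compound 2 (0.17 log units; within the scatter) lies within the scatter, so the two numbers stand together rather than apart. Compound 3 `O=C(CSc1nnc(-c2ccncc2)n1-c1ccccc1)N/N=C/C=C/c1ccccc1` has not yet been measured. It differs from compound 2 in one place: 2-phenylethenyl in place of 2-fluorophenyl on a carbon with a double bond to nitrogen. Among the compounds with values here, the one measured step that bears on this, a 1.5-fold higher number from compound 1 to compound 2 (0.17 log units; within the scatter), also exchanged the group on the carbon with a double bond to nitrogen and did not move the number beyond the scatter. Nothing measured here shows a change at that place shifting the number further, so compound 3 is expected to give a number near that of compound 2. The expected step is therefore a 1.1-fold lower number from compound 2 to compound 3 (0.05 log units; within the scatter). The estimate for compound 3 is 20000 nM, with a range from 8000 nM to 50000 nM.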

Compound 3, half-maximal inhibitory concentration: 11200 nM
The estimate for compound 3 lay 1.8-fold (0.25 log units) above the measured number; low and high end bracket the measured number.
By their numbers in this assay, from the lowest: compounds 3, 1 and 2 (each within the scatter of the next).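

In this assay, 2-phenylethenyl in place of 2-fluorophenyl on the carbon with a double bond to nitrogen gives a 2.0-fold lower number from compound 2 to compound 3 (0.30 log units; within the scatter) and 2-phenylethenyl in place of 4-nitrophenyl gives a 1.4-fold lower number from compound 1 to compound 3 (0.14 log units; within the scatter) at the same place. The earlier pair showed only an exchange of one substituted phenyl group for another, whereas these steps show that a group with a double bond outside aromatic rings also leaves the number within the scatter of both earlier compounds. Nothing available accounts for these numbers. The compounds shown all keep a six-membered aromatic ring of carbon in this group, so it remains open whether an amine, a carboxylic acid or a saturated alkyl chain at this place would move the number beyond the scatter. They also leave open whether 2-phenylethyl would stand with compound 3.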